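A few compounds are considered here, and "the series" means these few. Any claim that something is new, unique, unknown or untested is made for them only; others in the source may bear on it.

Working notes on the series.

The shared core is that of compound 1 `C=C[C@@H]1OC(c2ccc(Br)cc2)=N[C@H]1S`. In an assay on isolated protein for inhibition of matrix metalloproteinase-9 (Homo sapiens) (on this read-out higher numbers stand for weaker inhibition and lower numbers for stronger inhibition), compound 1 gives only a limit, > 100000 nM. Compound 2 `C=C[C@@H]1OC(c2ccc(Br)cc2)=N[C@H]1CO` gives 9000 nM in this assay, and compound 3 `C=C[C@@H]1OC(c2ccc(Br)cc2)=N[C@H]1Sc1ccccc1` gives 94000 nM. Of the two numbers shown compound 3 stands highest, with compound 2 nearest, the step of a 10-fold higher number from compound 2 to compound 3 (1.02 log units; beyond the scatter). The step of an at least 1.0-fold lower number from compound 1 to compound 3 (0.02 log units; that floor lies within the scatter) is bounded by the limit of compound 1 (the limit of > 100000 nM in this assay, at which 1 of the 3 values shown sits).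

Compound 4 `C=C[C@@H]1OC(c2ccc(Br)cc2)=N[C@H]1SC(C)=O` differs from compound 3 by acetyl in place of phenyl on a sulfur. Within the data shown here, the only measured step on the same sulfur is an at least 1.0-fold lower number from compound 1 to compound 3 (0.02 log units; that floor lies within the scatter), which did not move beyond the scatter; the large steps of an at least 11-fold lower number from compound 1 to compound 2 (1.04 log units; beyond the scatter) and a 10-fold higher number from compound 2 to compound 3 (1.02 log units; beyond the scatter) concern the ring carbon, not the sulfur substituent. A change of the sulfur substituent is therefore expected to give no step beyond the scatter in this assay, so that compound 4 is expected to show a 1.2-fold lower number from compound 3 to compound 4 (0.07 log units; within the scatter). Compound 4 is estimated at 80000 nM, within 20000 nM to 300000 nM.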

Compound 4, inhibition constant: 88000 nM
Compound 4: middle estimate off by 1.1-fold (0.04 log units), on the low side, and the stated range covers the measured number.
By their numbers in this assay, from the lowest: compound 2; then compounds 4 and 3 (each within the scatter of the next). At a limit, above all of these: compound 1.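

Acetyl in place of phenyl on a sulfur gives a 1.1-fold lower number from compound 3 to compound 4 (0.03 log units; within the scatter) in this assay, so this second measured pair of substituents, one with an aromatic ring and one with a carbonyl, is not told apart by this read-out. Exchanging hydroxymethyl for acetylsulfanyl on the saturated ring carbon gives a 9.8-fold higher number from compound 2 to compound 4 (0.99 log units; beyond the scatter), which leaves compound 2 with the lowest number shown and no sulfur-linked compound near it. The step of an at least 1.1-fold lower number from compound 1 to compound 4 (0.05 log units; that floor lies within the scatter) is bounded by the limit of compound 1: the limit of > 100000 nM in this assay, at which 1 of the 4 values shown sits.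

The compounds shown leave open whether an amine or a carboxylic acid on the sulfur would move the number beyond the scatter. They also leave open whether a longer chain ending in hydroxyl, in place of hydroxymethyl on the saturated ring carbon, would keep the number of compound 2.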